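Notes on a chloro-for-hydrogen step across four compounds

This account rests on a few compounds, and the source may have more. Where it says the series, first, only, none or still open, it means among the compounds named here.

Compound 1 `ClCc1ccc(Cn2cnc3c(Cl)ncnc32)cc1` is measured in a functional assay on SNB-19 cells (Homo sapiens) for cytotoxicity, read by sulforhodamine B assay, with a stated time of 48 h (on this read-out higher numbers stand for weaker inhibition of growth and lower numbers for stronger inhibition of growth), where compound 1 gives 3630 nM. Compound 3 `ClCc1ccc(Cn2cnc3c(Cl)nc(Cl)nc32)cc1` carries a single change, (chloro in place of hydrogen on an aromatic carbon), and in this assay compound 3 gives 2510 nM; the step is a 1.4-fold lower number from compound 1 to compound 3 (0.16 log units; within the scatter). Compound 2 `ClCc1cccc(Cn2cnc3ncnc(Cl)c32)c1` has the same atoms as compound 1 joined differently; the difference between the two cores is not broken down here, and in this assay compound 2 gives "not determined" (no result reported), so no number was recorded for it. Compound 4 `ClCc1cccc(Cn2cnc3nc(Cl)nc(Cl)c32)c1` is not yet measured; it differs from compound 2 by chloro in place of hydrogen on an aromatic carbon, the same change as that from compound 1 to compound 3. For the measured compounds named here, with no value for compound 2, the only anchor is compound 3, which gives 2510 nM, together with the step from compound 1 to compound 3 lying within the scatter. Compound 4 is therefore expected to give about 2800 nM in this assay, with a likely range from 1000 nM to 8000 nM.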

Compound 4, concentration for 50% growth inhibition: 1380 nM
Compound 4: the middle estimate sits 2.0-fold (0.31 log units) above what was measured; low and high end bracket the measured number.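

For the compounds shown here, compound 2 has no number in this assay, so no step from compound 2 to compound 4 can be read. The compounds shown leave open what chloro in place of hydrogen does on the core of compound 2. Nothing further is available to account for the value of compound 4.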